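This account rests on a few compounds, and the source may have more. Where it says the series, first, only, none or still open, it means among the compounds named here.

In a functional assay on DU-145 cells (Homo sapiens) for inhibition, read by trypan blue exclusion, with a stated time of 96 h (a higher number here means a weaker inhibitor of growth, a lower number a stronger inhibitor of growth), three compounds have been measured so far:

- compound 1 `Cc1ccc(S(=O)(=O)/C(=C/c2sccc2C)C(=O)c2ccc(Cl)cc2)cc1` gives 10000 nM in this test
- compound 2 `Cc1ccc(S(=O)(=O)/C(=C/c2ccc(Cl)cc2)C(=O)c2ccc(Cl)cc2)cc1` gives 1000 nM in this test
- compound 3 `Cc1ccc(S(=O)(=O)/C(=C/c2ccc(Oc3ccccc3)cc2)C(=O)c2ccc(Cl)cc2)cc1` gives 1000 nM in this test

Compound 2 stands level with compound 3, the two sharing the lowest number of the three, while compound 1 has the highest.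

The next structure is compound 4 `COc1ccc(/C=C(\C(=O)c2ccc(Cl)cc2)S(=O)(=O)c2ccc(C)cc2)cc1O`, which departs from compound 2 in one place. The difference is 3-hydroxy-4-methoxyphenyl in place of 4-chlorophenyl on a double-bonded chain carbon bound to a double-bonded chain carbon and it puts 3-hydroxy-4-methoxyphenyl in place of 4-chlorophenyl on a double-bonded chain carbon bound to a double-bonded chain carbon.

Within the data shown here, two measured steps bear on this. Exchanging the group at that same place, 4-chlorophenyl in place of 3-methylthiophen-2-yl, gave a 10-fold lower number from compound 1 to compound 2 (1.00 log units; beyond the scatter) as its result. Phenoxy in place of chloro on an aromatic carbon gave no change at the digits printed from compound 2 to compound 3 (within the scatter) as its result, so that exchange on the ring left the number where it was. Among the measured compounds shown here, no measured compound carries the 3-hydroxy-4-methoxyphenyl group, so the direction remains uncertain, with only a slight lean toward a lower number.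

The expected change is a 2.0-fold lower number from compound 2 to compound 4 (0.30 log units; within the scatter) on this reasoning. In this assay compound 4 is estimated at 500 nM with an expected range from 60 nM to 3000 nM as its bounds.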

Compound 4, concentration for 50% growth inhibition: 1000 nM
Beside the measured number, compound 4's estimate is 2.0-fold (0.30 log units) below it; the measured number falls inside the stated range.
By their numbers in this assay, from the lowest: compounds 2, 3 and 4 (each within the scatter of the next); then compound 1.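

At this position on a double-bonded chain carbon, in this assay, the exchange of 4-chlorophenyl for 3-hydroxy-4-methoxyphenyl gave no change at the digits printed from compound 2 to compound 4 (within the scatter), even though the entering group counts a hydrogen-bond donor and two hydrogen-bond acceptors where the leaving group counts none. The earlier compounds had shown this flat result only for phenoxy in place of chloro on the ring, whereas compound 4 extends it to a different set of ring substituents, and the replacement of 3-methylthiophen-2-yl at the same place gave a 10-fold lower number from compound 1 to compound 4 (1.00 log units; beyond the scatter), so that compound 1 remains the one compound apart from the other three. No supporting data bear on why the number stays level across these ring substituents or why compound 1 stands apart.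

The compounds shown leave open whether a hydroxy or a methoxy group alone on the ring would give the same number as the pair in compound 4, and whether the level would hold with an amine or a carboxylic acid on that ring. They also leave open whether the gap to compound 1 follows from its sulfur-containing ring or from the methyl group on that ring.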